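A few compounds are considered here, and "the series" means these few. Any claim that something is new, unique, unknown or untested is made for them only; others in the source may bear on it.

Compound 1 `COc1nc2ccccc2cc1/C=C/c1noc(-c2ccc(C)cc2)n1` in an ADME assay on HepG2 cells (Homo sapiens) for cytotoxicity, read by sulforhodamine B assay, with a stated time of 48 h (a higher number here means that more compound is tolerated, a lower number that less compound is tolerated), gives > 230000 nM, a limit of this assay.
Compound 2 `COc1ccc(-c2nc(/C=C/c3cc4ccccc4nc3OC)no2)cc1` in this assay gives > 220000 nM, a limit.
Compound 3 `COc1nc2ccccc2cc1/C=C/c1noc(-c2ccccc2C)n1` in this assay gives > 230000 nM, a limit.

Compound 3 stands only at a limit; the two other values are limits as well, one at the limit of > 220000 nM in this assay, at which 1 of the 3 values shown sits, and two at the limit of > 230000 nM in this assay, at which 2 of the 3 values shown sit. Compound 4 `COc1nc2ccccc2cc1/C=C/c1noc(-c2ccccc2Br)n1` differs from compound 3 by bromo in place of methyl on an aromatic carbon. Within the data shown here, the steps that bear on this change, a step that the two limits leave unreadable from compound 1 to compound 2, a step that the two limits leave unreadable from compound 1 to compound 3 and a step that the two limits leave unreadable from compound 2 to compound 3, are all unreadable, since both ends of each sit at a limit. Among the measured compounds shown here, no step in this assay has been measured with a size, so no shift beyond the scatter is expected for compound 4, whose value is estimated at 230000 nM (100000 nM to 500000 nM), an expected step of a number no higher from compound 3 to compound 4 (the limit leaves the size open) that will most likely again be reported as a limit.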

Compound 4, half-maximal cytotoxic concentration: > 195000 nM
Compound 4 ended at the assay's limit (the forecaster's own chance of this, stated with the estimate: 75%); the middle value is on the limit's open side.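

Compound 4, like compound 1, compound 2 and compound 3, stands at a limit in this assay, and no step among these compounds can be read. The compounds shown leave open at what concentration any of them turns cytotoxic.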